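Swapping the Benzyloxy Side Group for a Single Chlorine

The source may hold more compounds than are shown below. What is called first, only, known or untested is meant among the compounds shown, and "the series" means these compounds.

Compound 1 `CC(C(=O)NCc1ccc(C(F)(F)F)cc1N1CCCCCC1)c1ccc(NS(C)(=O)=O)c(F)c1`: 1.6 nM
Compound 2 `CC1CCN(c2cc(C(F)(F)F)ccc2CNC(=O)C(C)c2ccc(NS(C)(=O)=O)c(F)c2)CC1`: 0.9 nM
Compound 3 `CC(C(=O)NCc1ccc(C(F)(F)F)cc1OCc1ccc(F)cc1)c1ccc(NS(C)(=O)=O)c(F)c1`: 0.5 nM

All three share one core and differ only in the group on one aromatic carbon, and all were tested in an assay on CHO cells for antagonist activity at transient receptor potential cation channel subfamily V member 1 (Homo sapiens), read by FLIPR; on this read-out lower numbers stand for stronger inhibition and higher numbers for weaker inhibition. Compound 3 gives the lowest of the three numbers, with a 3.2-fold lower number from compound 1 to compound 3 (0.51 log units; beyond the scatter) and a 1.8-fold lower number from compound 2 to compound 3 (0.26 log units; within the scatter). Compound 4 `CC(C(=O)NCc1ccc(C(F)(F)F)cc1Cl)c1ccc(NS(C)(=O)=O)c(F)c1` has not yet been measured. It differs from compound 3 in one place: chloro in place of (4-fluorobenzyl)oxy on an aromatic carbon. Within the data shown here, the measured steps of a 1.8-fold lower number from compound 1 to compound 2 (0.25 log units; within the scatter), a 3.2-fold lower number from compound 1 to compound 3 (0.51 log units; beyond the scatter) and a 1.8-fold lower number from compound 2 to compound 3 (0.26 log units; within the scatter) each exchange one ring-bearing group for another at this carbon; none of them shrinks the group to a single atom, so no measured step bears directly on this change. Some loss of potency is nevertheless expected, and compound 4 is estimated at 8 nM, between 2 nM and 40 nM, an expected step of a 16-fold higher number from compound 3 to compound 4 (1.20 log units; beyond the scatter).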

Compound 4, inhibition constant: 4 nM
Estimate against measurement, compound 4: 2.0-fold (0.30 log units) above; measured number inside the range.
By their numbers in this assay, from the lowest: compounds 3, 2 and 1 (each within the scatter of the next, the first and the last beyond it); then compound 4.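

Cutting the group on this aromatic carbon down to a single chlorine atom produces a loss beyond the scatter against all three ring-bearing groups, with an 8.0-fold higher number from compound 3 to compound 4 (0.90 log units; beyond the scatter) and a 4.4-fold higher number from compound 2 to compound 4 (0.65 log units; beyond the scatter) and a 2.5-fold higher number from compound 1 to compound 4 (0.40 log units; beyond the scatter) in turn. A ring in this group is therefore not required for activity, since compound 4 keeps a low number, but each ring-bearing group gives a lower one. Nothing measured here explains this difference.

Still open, from the compounds shown here alone, is how a plain hydrogen, a methoxy group or a small amine such as dimethylamino would compare at this carbon. Also open, going by these compounds, is whether the (4-fluorobenzyl)oxy group needs its fluorine.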